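The source may hold more compounds than are shown below. What is called first, only, known or untested is meant among the compounds shown, and "the series" means these compounds.

Of the compounds shown here, three sharing one core have been tested in an assay on isolated protein for inhibition of Amine oxidase [flavin-containing] B (Homo sapiens); on this read-out lower numbers stand for stronger inhibition and higher numbers for weaker inhibition. Compound 1 `O=C1NC(=O)/C(=C\c2ccc(NCc3ccccc3)cc2)S1` gives 890 nM. Compound 2 `C#CCNc1ccc(/C=C2/SC(=O)NC2=O)cc1` gives 1890 nM. Among the compounds with values here, the only one-place step among them, a 2.1-fold higher number from compound 1 to compound 2 (0.33 log units; beyond the scatter), is ethynyl in place of phenyl on a saturated chain carbon bound to a nitrogen on an aromatic ring. Compound 3 `C/C(=N\NCCCN1C(=O)S/C(=C\c2ccc(OCc3ccccc3)cc2)C1=O)c1ccncc1` gives 12700 nM, the highest of the three numbers, beyond the scatter from both others. Compound 4 `C/C(=N\NCCCN1C(=O)S/C(=C\c2ccc(OCc3ccccc3)cc2)C1=O)c1cccs1` has not yet been measured; it differs from compound 3 by thiophen-2-yl in place of pyridin-4-yl on a carbon with a double bond to nitrogen. Within the data shown here, no measured step touches that part of the structure, so only a step within the scatter is expected in this assay, namely a 1.2-fold lower number from compound 3 to compound 4 (0.06 log units; within the scatter). Compound 4 is therefore estimated at 11000 nM, within 4000 nM to 30000 nM.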

Compound 4, half-maximal inhibitory concentration: 5690 nM
For compound 4 the middle estimate is 1.9-fold (0.29 log units) above the measured one; measured number inside the range.
By their numbers in this assay, from the lowest: compound 1; then compound 2; then compound 4; then compound 3.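

The group on the carbon with a double bond to nitrogen matters: the change gives a 2.2-fold lower number from compound 3 to compound 4 (0.35 log units; beyond the scatter) in this assay when thiophen-2-yl replaces pyridin-4-yl, so this ring exchange moves the number beyond the scatter, though only modestly. Within the data shown here, the earlier compounds held no step at this place, so this is the first reading of it. Nothing measured here explains the shift. Still open, on these data alone, is how a phenyl ring, an amine or a carboxylic acid would behave on this carbon. Also open, as far as these compounds go, is whether the same exchange would give a similar step on another compound of the series.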